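The source may hold more compounds than are shown below. What is called first, only, known or untested is meant among the compounds shown, and "the series" means these compounds.

Measured so far:
- compound 1 `Cc1cc(NC(=O)Cn2nnc(-c3ccccc3)n2)n(CC2CCCCC2)n1`: 77%
- compound 2 `Cc1cc(NC(=O)Cn2nnc(-c3ccc(F)c(F)c3)n2)n(C2CCCCC2)n1`: 93%

In an assay on HEK293 cells for activation of Kir3.1/Kir3.2 (Homo sapiens), read by thallium flux (on this read-out lower numbers stand for smaller maximal responses and higher numbers for larger maximal responses), compound 2 stands highest of the two numbers; the nearest is compound 1, whose value lies lower by a gap beyond the scatter. Compound 3 `Cc1cc(NC(=O)Cn2nnc(-c3ccc(Cl)c(C)c3)n2)n(C2CCCCC2)n1` differs from compound 2 in one place: 4-chloro-3-methylphenyl in place of 3,4-difluorophenyl on an aromatic carbon. For the measured compounds named here, no pair of measured compounds isolates this change, so the step can only be estimated. The step of a number 5 percentage points lower from compound 2 to compound 3 (within the scatter) is expected to be none beyond the scatter, leaning slightly lower. Compound 3 is expected to give 88% in this assay, within the range 74% to 102%.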

Compound 3, largest response reached (Emax), in percent of the reference or control that the assay uses: 89%
Beside the measured number, compound 3's estimate is 1 percentage points below it, and the stated range covers the measured number.
By their numbers in this assay, from the lowest: compound 1; then compounds 3 and 2 (each within the scatter of the next).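

In this assay, 4-chloro-3-methylphenyl in place of 3,4-difluorophenyl on the aromatic carbon of the five-membered ring gives a number 4 percentage points lower from compound 2 to compound 3 (within the scatter), so this position accepts both substituted phenyl groups with no difference beyond the scatter. Both groups hold 8 heavy atoms and no hydrogen-bond donors or acceptors, so the comparison covers only a narrow range of groups. Nothing measured on these compounds explains this result.

Still open, from the compounds shown here alone, is whether a phenyl bearing a carboxylic acid or an amine keeps the response at this position. A single pair also cannot show how far this tolerance extends across the series.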